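Taking the Nitro Group Off Compound 3

A few compounds are considered here, and "the series" means these few. Any claim that something is new, unique, unknown or untested is made for them only; others in the source may bear on it.

In a functional assay on A549 cells (Homo sapiens) for antiproliferative activity, read by MTT assay, with a stated time of 48 h (on this read-out higher numbers stand for weaker inhibition and lower numbers for stronger inhibition), compound 1 `COc1ccc2nc(NC(c3cn(-c4ccccc4)nc3-c3ccc([N+](=O)[O-])cc3)c3c(O)ccc4ccccc34)sc2c1` gives 22500 nM, compound 2 `COc1ccc2nc(NC(c3cn(-c4ccccc4)nc3-c3ccc(F)cc3)c3c(O)ccc4ccccc34)sc2c1` gives 33600 nM and compound 3 `COc1ccc2nc(NC(c3cn(-c4ccccc4)nc3-c3cccc([N+](=O)[O-])c3)c3c(O)ccc4ccccc34)sc2c1` gives 52200 nM, the highest of these three numbers. Compound 4 `COc1ccc2nc(NC(c3cn(-c4ccccc4)nc3-c3ccccc3)c3c(O)ccc4ccccc34)sc2c1` differs from compound 3 by one change, hydrogen in place of nitro on an aromatic carbon. Within the data shown here, no measured step removes a group outright, so the nearest guides are swaps on this same ring: a 1.5-fold higher number from compound 1 to compound 2 (0.17 log units; within the scatter), a 1.6-fold higher number from compound 2 to compound 3 (0.19 log units; within the scatter) and a 2.3-fold higher number from compound 1 to compound 3 (0.37 log units; beyond the scatter). All three are small. In this assay the expected step is therefore also small, toward a lower number: a 1.5-fold lower number from compound 3 to compound 4 (0.17 log units; within the scatter). Compound 4 is expected to give 35000 nM, with an estimated range of 16000 nM to 70000 nM.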

Compound 4, half-maximal inhibitory concentration: 44600 nM
Estimate against measurement, compound 4: 1.3-fold (0.11 log units) below; measured number inside the range.
By their numbers in this assay, from the lowest: compounds 1, 2, 4 and 3 (each within the scatter of the next, the first and the last beyond it).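

Stripping this ring down to plain phenyl changes little in this assay: hydrogen in place of nitro gives a 1.2-fold lower number from compound 3 to compound 4 (0.07 log units; within the scatter) and hydrogen in place of fluoro gives a 1.3-fold higher number from compound 2 to compound 4 (0.12 log units; within the scatter). Hydrogen in place of nitro at the other ring position gives a 2.0-fold higher number from compound 1 to compound 4 (0.30 log units; within the scatter) and also stays within the scatter. So neither nitro nor fluoro is shown to be needed on this ring for the activity seen here.

Nothing measured here bears on why these steps are so small. As far as these compounds go, whether an amine or a carboxylic acid on this ring would shift the number further remains open.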